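Adding a 2-Carboxyethyl Arm to Compound 3

The compounds below may be only part of what the source reports. "The series", "measured", "known", "first", "only" and "open" are said of these compounds alone.

Compound 3 `O=C(O)CNC(=O)CN(c1nc(Cl)nc2[nH]cnc12)C1CC1` carries the shared core on a short amide chain. In a functional assay on the whole organism (Tail, strain ICR) with Mus musculus as the target, in the tail flick test, with a stated time of 150 min, at a dose of 25 umol/kg by the oral route (on this read-out higher numbers stand for a stronger effect at the one dose given and lower numbers for a weaker effect), compound 3 gives 9.08%. Compound 1 `N=C(N)NCCC[C@H](NC(=O)CN(c1nc(Cl)nc2[nH]cnc12)C1CC1)C(=O)O` gives 7.19% and compound 2 `O=C(CN(c1nc(Cl)nc2[nH]cnc12)C1CC1)N[C@@H](CO)C(=O)O` gives 18.8%; both numbers lie within the usual scatter of compound 3, so none of the three can be set apart from the others. Compound 4 `O=C(O)CC[C@H](NC(=O)CN(c1nc(Cl)nc2[nH]cnc12)C1CC1)C(=O)O` differs from compound 3 by 2-carboxyethyl in place of hydrogen on a saturated chain carbon bound to an amide-type nitrogen and a carbonyl carbon. Among the compounds with values here, two measured steps touch this position: a number 9.7 percentage points lower from compound 2 to compound 3 (within the scatter) and a number 1.9 percentage points higher from compound 1 to compound 3 (within the scatter). Neither the hydroxymethyl group nor the group of 7 heavy atoms moved the read-out beyond the scatter, so the 2-carboxyethyl group is expected to bring a number 2.9 percentage points higher from compound 3 to compound 4 (within the scatter), a step that stays within the scatter. Compound 4 is therefore estimated at 12%, with a range from 3% to 25%.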

Compound 4, a percentage reported as activity, at one dose (the size of the read-out at that dose, not a potency): 29.5%
For compound 4 the middle estimate is 17.5 percentage points below the measured one; the measured number lies above the stated range.
By their numbers in this assay, from the lowest: compounds 1, 3 and 2 (each within the scatter of the next, the first and the last beyond it); then compound 4.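

In this assay, within the data shown here, 2-carboxyethyl is the first group on this saturated chain carbon to clear the scatter against hydrogen, with a number 20.4 percentage points higher from compound 3 to compound 4 (beyond the scatter). It also clears the scatter against the other two side chains, with a number 10.7 percentage points higher from compound 2 to compound 4 (beyond the scatter) and a number 22.3 percentage points higher from compound 1 to compound 4 (beyond the scatter), so compound 4 has the highest number of the four.

As far as these compounds go, whether a shorter carboxymethyl group, a longer chain ending in a carboxylic acid, or the same chain ending in a primary amide would give a similar number stays open. Nothing given here explains the rise.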